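Chloro in Place of Bromo: From Compound 2 to Compound 3

This account rests on a few compounds, and the source may have more. Where it says the series, first, only, none or still open, it means among the compounds named here.

Of the compounds shown here, two sharing one core have been measured in a functional assay on B16-F10 cells (Mus musculus) for antiproliferative activity, read by MTT assay, with a stated time of 48 h; on this read-out higher numbers stand for weaker inhibition and lower numbers for stronger inhibition. Compound 1 `Cc1ccc(NCc2cn(-c3ccccc3)nc2-c2ccc(Cl)cc2)cc1` gives 3480 nM in this assay. Compound 2 `Fc1ccc(NCc2cn(-c3ccccc3)nc2-c2ccc(Br)cc2)cc1` gives 4180 nM in this assay. Going by the values given here, compound 2 holds the higher of the two numbers, but its only neighbour, compound 1, sits within the usual scatter of it, so the two values cannot be told apart and neither compound can be called the weaker or the stronger. Compound 3 `Fc1ccc(NCc2cn(-c3ccccc3)nc2-c2ccc(Cl)cc2)cc1` has not yet been measured. It differs from compound 2 in one place: chloro in place of bromo on an aromatic carbon. Among the compounds with values here, compound 1 already carries the chloro group on the same ring, though it also differs from compound 2 elsewhere, so no clean step for this single change exists among the measured pair. On what the two values show, the author expects no change beyond the scatter, a step of a 1.1-fold lower number from compound 2 to compound 3 (0.03 log units; within the scatter) in this assay. Compound 3 is therefore estimated to give 3900 nM in this assay, with a range from 1900 nM to 8000 nM.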

Compound 3, half-maximal inhibitory concentration: 2120 nM
Compound 3: middle estimate off by 1.8-fold (0.26 log units), on the high side; low and high end bracket the measured number.
By their numbers in this assay, from the lowest: compounds 3, 1 and 2 (each within the scatter of the next).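

In this assay the change from 4-bromophenyl to 4-chlorophenyl can now be read on its own, as a 2.0-fold lower number from compound 2 to compound 3 (0.29 log units; within the scatter). At this place, para to a large group, the two halogens therefore cannot be told apart in this read-out, something the earlier pair could not show because its two compounds differed in more than one place. The new compound also gives a second single change, fluoro in place of methyl on an aromatic carbon, read as a 1.6-fold lower number from compound 1 to compound 3 (0.22 log units; within the scatter), so this exchange likewise gives no difference that stands clear of the scatter, and nothing at hand offers an explanation for either result.

What the compounds shown leave open is whether any group at these two places can move the number beyond the scatter, since only chloro and bromo have been compared at one and only fluoro and methyl at the other. An amine or a carboxylic acid in place of the chloro group, or a methoxy group or a longer chain in place of the fluoro group, remains untested among these compounds.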